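The source may hold more compounds than are shown below. What is called first, only, known or untested is meant among the compounds shown, and "the series" means these compounds.

Measured in a functional assay on COLO 205 cells (Homo sapiens) for cytotoxicity, read by MTT assay, with a stated time of 24 h; a higher number here means a weaker inhibitor, a lower number a stronger inhibitor:
compound 1 `COc1ccc(/C=C\C(=O)O)c(OCc2cn(-c3ccccc3)nn2)c1CC=C(C)C` gives 32300 nM
compound 2 `COc1ccc(/C=C\C(=O)O)c(OCc2cn(-c3ccc(CO)cc3)nn2)c1CC=C(C)C` gives 19300 nM
compound 3 `COc1ccc(/C=C\C(=O)O)c(OCc2cn(-c3nc4ccccc4s3)nn2)c1CC=C(C)C` gives 20200 nM

Compound 3 stands second highest of these three numbers, with compound 2 nearest and compound 1 furthest; the steps of a 1.0-fold higher number from compound 2 to compound 3 (0.02 log units; within the scatter) and a 1.6-fold lower number from compound 1 to compound 3 (0.20 log units; within the scatter) both lie within the scatter, so the three values cannot be ordered. Compound 4 `COc1ccc(/C=C\C(=O)O)c(OCc2cn(-c3ccccc3C#N)nn2)c1CC=C(C)C` differs from compound 3 in one place: 2-cyanophenyl in place of 1,3-benzothiazol-2-yl on an aromatic nitrogen. Among the compounds with values here, the steps that bear on it are those that also exchange the group on the aromatic nitrogen, a 1.6-fold lower number from compound 1 to compound 3 (0.20 log units; within the scatter) and a 1.0-fold higher number from compound 2 to compound 3 (0.02 log units; within the scatter), neither beyond the scatter, and a 1.7-fold lower number from compound 1 to compound 2 (0.22 log units; within the scatter) points the same way. Compound 4 is therefore expected to show no step beyond the scatter, a 1.2-fold higher number from compound 3 to compound 4 (0.07 log units; within the scatter). The estimate for compound 4 in this assay is 24000 nM, within 9000 nM to 60000 nM.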

Compound 4, half-maximal inhibitory concentration: 3200 nM
Compound 4: middle estimate off by 7.5-fold (0.88 log units), on the high side; measured number below the stated range.
By their numbers in this assay, from the lowest: compound 4; then compounds 2, 3 and 1 (each within the scatter of the next).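

In this assay, the group on the aromatic nitrogen now moves the number beyond the scatter, which no earlier exchange did: the steps are a 6.3-fold lower number from compound 3 to compound 4 (0.80 log units; beyond the scatter) and a 6.0-fold lower number from compound 2 to compound 4 (0.78 log units; beyond the scatter), both with 2-cyanophenyl entering. Within the data shown here, with cyano in place of hydrogen on an aromatic carbon as the only change, a 10-fold lower number from compound 1 to compound 4 (1.00 log units; beyond the scatter) is seen on the phenyl group. Nothing available explains this result. The compounds shown leave open whether an amine or a carboxylic acid in place of cyano would give a similar step, and whether cyano on another ring carbon would.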